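Moving a Chlorine on the Benzyl Arm of a Dihydropyrimidine

A few compounds are considered here, and "the series" means these few. Any claim that something is new, unique, unknown or untested is made for them only; others in the source may bear on it.

Compound 1 `CC1=C(C(=O)Nc2ccc(F)cc2)C(c2ccc([N+](=O)[O-])cc2)N=C(SCc2cccc(Cl)c2)N1` and compound 2 `CC1=C(C(=O)Nc2ccc(F)cc2)C(c2ccc([N+](=O)[O-])cc2)N=C(SCc2ccc(Cl)cc2)N1` share one core; compound 3 `COc1ccc(C2N=C(SCc3cccc(Cl)c3)NC(C)=C2C(=O)Nc2ccc(Br)cc2)cc1` and compound 4 `COc1ccc(C2N=C(SCc3ccc(Cl)cc3)NC(C)=C2C(=O)Nc2ccc(Br)cc2)cc1` share another, and the difference between the two cores is not broken down here. In a functional assay on the whole organism (artery, strain albino) with Rattus norvegicus as the target, with a stated time of 240 min, at a dose of 10 mg/kg by the oral route (on this read-out lower numbers stand for less inhibition and higher numbers for more inhibition at the one dose given (going by the name of the read-out)), compound 1 gives 15.9%, compound 2 gives 33.3% and compound 3 gives 33.8%. Going by the values given here, the one counted change within each pair is 4-chlorophenyl in place of 3-chlorophenyl on a saturated chain carbon bound to a sulfur, and the same change, (4-chlorophenyl in place of 3-chlorophenyl on a saturated chain carbon bound to a sulfur), carries compound 3 into compound 4. Measured once, it made a number 17.4 percentage points higher from compound 1 to compound 2 (beyond the scatter). The step from compound 3 to compound 4 in this assay is expected to be a number 12.2 percentage points higher from compound 3 to compound 4 (beyond the scatter), resting on that single earlier step and on its distance from the usual scatter, with some caution. That earlier step is seen only once. Compound 4 is therefore estimated at 46%, somewhere between 30% and 62%.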

Compound 4, a percentage reported as inhibition, in the whole organism at one dose (the size of the read-out at that dose, not a potency): 29.2%
Compound 4: the middle estimate sits 16.8 percentage points above what was measured; measured number below the stated range.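

Moving the chlorine does not carry over from one core to the other in this assay: the same change on two cores in this assay, a number 17.4 percentage points higher (beyond the scatter) from compound 1 to compound 2 and a number 4.6 percentage points lower (within the scatter) from compound 3 to compound 4, 22 percentage points apart, beyond the scatter of two such steps. On the core of compound 3, the step is a number 4.6 percentage points lower from compound 3 to compound 4 (within the scatter), so compound 3 and compound 4 cannot be told apart in this measurement. The result shows that the step on the core of compound 1 is a poor guide to the core of compound 3, but it does not show which part of the cores sets them apart, and each step rests on a single pair.

Still open, as far as these compounds go, is how a plain benzyl group or a longer alkyl chain on the sulfur would compare with either chlorobenzyl group. Also open, from the compounds shown here alone, is how this change would behave on a third core.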